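The source may hold more compounds than are shown below. What is called first, only, known or untested is meant among the compounds shown, and "the series" means these compounds.

Working notes on the series. All three measured members share the core of compound 1 `CCc1nnc(SCC(=O)c2ccc(Cl)cc2)n1N1C(=O)c2ccccc2C1=O`. In a functional assay on MKN-45 cells (Homo sapiens) for cytotoxicity, read by MTT assay, with a stated time of 48 h (a lower number here means a stronger inhibitor, a higher number a weaker inhibitor), compound 1 gives only a limit, > 200000 nM. Compound 2 `CCc1nnc(SCC(=O)c2ccc(C)cc2)n1N1C(=O)c2ccccc2C1=O` carries methyl in place of chloro on an aromatic carbon. In this assay compound 2 likewise gives only a limit, > 200000 nM. The two limits leave a step that the two limits leave unreadable from compound 1 to compound 2 unreadable in size. Compound 3 `CCCc1nnc(SCC(=O)c2ccc(Cl)cc2)n1N1C(=O)c2ccccc2C1=O` differs from compound 1 by methyl in place of hydrogen on a saturated chain carbon, two bonds along the chain from an aromatic carbon. In this assay compound 3 also gives only a limit, > 200000 nM. The step that the two limits leave unreadable from compound 1 to compound 3 is thus unreadable as well. Compound 4 `CCCc1nnc(SCC(=O)c2ccc(C)cc2)n1N1C(=O)c2ccccc2C1=O` is not yet measured; it differs from compound 3 by methyl in place of chloro on an aromatic carbon, the same change as from compound 1 to compound 2, at the same place. Because the limit of > 200000 nM in this assay, at which 3 of the 3 values shown sit, holds every value shown, compound 4 is expected to sit at that limit too, with an expected step that the limit leaves unreadable from compound 3 to compound 4. The estimate for compound 4 in this assay is 300000 nM, between 150000 nM and 1000000 nM.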

Compound 4, half-maximal inhibitory concentration: > 200000 nM
Compound 4: only a limit was reported; the forecaster's own chance of this, stated with the estimate: 90%; the middle value does not contradict the limit.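

The steps from compound 3 and from compound 2 to compound 4 cannot be read in this assay because all four compounds sit at one limit: the limit of > 200000 nM in this assay, at which 4 of the 4 values shown sit. The compounds shown leave open whether either change affects cytotoxicity in this assay at all.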